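This account rests on a few compounds, and the source may have more. Where it says the series, first, only, none or still open, it means among the compounds named here.

Measured so far in an ADME assay on microsomes from liver (Mus musculus) for metabolic stability; a higher number here means faster removal of the compound, a lower number slower removal:
Compound 1 `Cc1n[nH]c(-c2ncc3cccnc3c2O)n1`: 3.3 mL.min-1.g-1
Compound 2 `Cc1n[nH]c(-c2ncc3c(-c4ccccc4C(F)(F)F)ccnc3c2O)n1`: 1.4 mL.min-1.g-1

Compound 2, at 1.4 mL.min-1.g-1, has the lower of the two numbers, and its gap to compound 1 lies beyond the usual scatter. The next compound to be tested is compound 3 `COc1ccccc1-c1ccnc2c(O)c(-c3nc(C)n[nH]3)ncc12`. It differs from compound 2 by one swap, methoxy in place of trifluoromethyl on an aromatic carbon, ortho to a large group: methoxy in place of trifluoromethyl on an aromatic carbon. For the measured compounds named here, no measured pair shows this swap, so the expectation is only tentative: a small rise in the number in this assay, possibly none beyond the scatter. The value of compound 1, 3.3 mL.min-1.g-1, serves as a rough guide to the upper side. The expected change is a 1.4-fold higher number from compound 2 to compound 3 (0.15 log units; within the scatter). For compound 3 the estimated value is 2 mL.min-1.g-1, with an expected range of 0.9 mL.min-1.g-1 to 4.5 mL.min-1.g-1.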

Compound 3, intrinsic clearance in microsomes: 0.8 mL.min-1.g-1
For compound 3 the middle estimate is 2.5-fold (0.40 log units) above the measured one, outside the stated range (below it).
By their numbers in this assay, from the lowest: compounds 3 and 2 (each within the scatter of the next); then compound 1.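

In this assay, swapping trifluoromethyl for methoxy on the phenyl ring gives a 1.8-fold lower number from compound 2 to compound 3 (0.24 log units; within the scatter), so the two groups cannot be told apart at this place on the ring, and the low number does not depend on trifluoromethyl. Set against the bare core, the whole 2-methoxyphenyl group in place of hydrogen gives a 4.1-fold lower number from compound 1 to compound 3 (0.62 log units; beyond the scatter), which is a step that can be read with confidence and shows that a substituted phenyl ring on this aromatic carbon can go with slower removal. No measurement shown here explains why these numbers fall as they do.

On these data alone, what stays open is how much of this comes from the phenyl ring itself and how much from the group it carries. A phenyl ring with only hydrogen at that place, or one bearing an amine or a carboxylic acid there, would help to separate the two.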